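Microsomal clearance notes: from compound 2 to compound 3

A few compounds are considered here, and "the series" means these few. Any claim that something is new, unique, unknown or untested is made for them only; others in the source may bear on it.

Measured so far:
- compound 1, `O=C(NCc1cc(Cl)ccc1-n1cnnn1)[C@@H]1C[C@@H]2C[C@@H]2N1C(=O)[C@H](O)CC1CC1`: < 12 mL.min-1.g-1
- compound 2, `Cc1cccc([C@@H](O)C(=O)N2N=CC[C@H]2C(=O)NCc2cc(Cl)ccc2-n2cnnn2)c1`: < 12 mL.min-1.g-1

In an ADME assay on liver for metabolic stability, with Liver microsome (Homo sapiens) as the target, read by LC-MS, using microsomes (on this read-out lower numbers stand for slow clearance and higher numbers for fast clearance), compound 1 gives < 12 mL.min-1.g-1, a limit of the assay. Compound 2 gives < 12 mL.min-1.g-1 in this assay, again a limit. Going by the values given here, both values sit at the limit of < 12 mL.min-1.g-1 in this assay, at which 2 of the 2 values shown sit, so compound 2 stands where the only other measured compound stands. Compound 3, `O=C(NCc1cc(Cl)ccc1-n1cnnn1)[C@@H]1CC=NN1C(=O)[C@H](O)c1ccccc1F`, differs from compound 2 by 2-fluorophenyl in place of 3-methylphenyl on a saturated chain carbon bound to a carbonyl carbon and an oxygen on a saturated carbon. Among the compounds with values here, no step between measured compounds is available to scale this change, so in this assay the step that the limit leaves unreadable from compound 2 to compound 3 is expected to be none beyond the scatter. Compound 3 is therefore estimated at 10 mL.min-1.g-1, between 3 mL.min-1.g-1 and 25 mL.min-1.g-1.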

Compound 3, intrinsic clearance in microsomes: 16 mL.min-1.g-1
The estimate for compound 3 lay 1.6-fold (0.20 log units) below the measured number; the measured number falls inside the stated range.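

In this assay, 2-fluorophenyl in place of 3-methylphenyl at this position gives an at least 1.3-fold higher number from compound 2 to compound 3 (0.12 log units; that floor lies within the scatter). Compound 3 is the only compound shown with a number rather than a limit, so this position now has one readable value. The true size of the step stays unknown because compound 2 sits at a limit: the limit of < 12 mL.min-1.g-1 in this assay, at which 2 of the 3 values shown sit.

Open, on these data alone, is whether the fluorine, its place on the ring or the loss of the methyl matters here. An unsubstituted phenyl or a carboxylic acid at this position would be needed to separate these readings.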